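Bromofluorophenyl change on a methylated core: estimating compound 4

A few compounds are considered here, and "the series" means these few. Any claim that something is new, unique, unknown or untested is made for them only; others in the source may bear on it.

Measured compounds:
compound 1, `O=C(Nc1ccc(Oc2ccnc3[nH]ccc23)c(F)c1)c1nn(-c2ccccc2)ccc1=O`, 38600 nM
compound 2, `O=C(Nc1ccc(Oc2ccnc3[nH]ccc23)c(F)c1)c1nn(-c2ccc(Br)cc2F)ccc1=O`, 8800 nM
compound 3, `Cn1ccc2c(Oc3ccc(NC(=O)c4nn(-c5ccccc5)ccc4=O)cc3F)ccnc21`, > 60000 nM

In a functional assay on PC-3 cells (Homo sapiens) for cytotoxicity, read by MTT assay, with a stated time of 72 h (on this read-out lower numbers stand for stronger inhibition and higher numbers for weaker inhibition), compound 1 gives 38600 nM. Compound 2 differs from it by 4-bromo-2-fluorophenyl in place of phenyl on an aromatic nitrogen, and this change brings a 4.4-fold lower number from compound 1 to compound 2 (0.64 log units; beyond the scatter). Compound 3 has a different core: it differs from compound 1 by methyl in place of hydrogen on an aromatic nitrogen. The value of compound 3 is a limit of this assay, not a number, namely (the limit of > 60000 nM in this assay, at which 1 of the 3 values shown sits); the step of an at least 1.5-fold higher number from compound 1 to compound 3 (0.19 log units; that floor lies within the scatter) therefore only sets a floor.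

Compound 4, `Cn1ccc2c(Oc3ccc(NC(=O)c4nn(-c5ccc(Br)cc5F)ccc4=O)cc3F)ccnc21`, is not yet measured. It differs from compound 3 by 4-bromo-2-fluorophenyl in place of phenyl on an aromatic nitrogen, the same change as that from compound 1 to compound 2, made at the same place. For compound 4 the step of an at least 2.4-fold lower number from compound 3 to compound 4 (0.38 log units; beyond the scatter) is expected, resting on the step of a 4.4-fold lower number from compound 1 to compound 2 (0.64 log units; beyond the scatter) seen between compound 1 and compound 2. Compound 4 is accordingly estimated at 25000 nM, with a likely range from 8000 nM to 60000 nM, and a real chance that this assay again reports only a limit.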

Compound 4, half-maximal inhibitory concentration: 16300 nM
Estimate against measurement, compound 4: 1.5-fold (0.19 log units) above, within the range that was stated.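

In this assay, the 4-bromo-2-fluorophenyl change goes the same way on the methylated core, with an at least 3.6-fold lower number from compound 3 to compound 4 (0.56 log units; beyond the scatter), so the direction holds on both cores shown: the same change on two cores in this assay, a 4.4-fold lower number (0.64 log units; beyond the scatter) from compound 1 to compound 2 and an at least 3.6-fold lower number (0.56 log units; beyond the scatter) from compound 3 to compound 4; the limit leaves it open whether they differ Compound 3 carries a limit, > 60000 nM, not a number, so the true size of the step on this core stays unknown. Methyl in place of hydrogen on the aromatic nitrogen gives a 1.9-fold higher number from compound 2 to compound 4 (0.27 log units; within the scatter), so this pair cannot be told apart, and two cores are too few to make either change a rule for other cores: the same change on two cores in this assay, an at least 1.5-fold higher number (0.19 log units; that floor lies within the scatter) from compound 1 to compound 3 and a 1.9-fold higher number (0.27 log units; within the scatter) from compound 2 to compound 4; the limit leaves it open whether they differ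

The compounds shown leave open whether the bromine, the fluorine or the two together account for the step, since the two enter together here. They also leave open how the change behaves with a longer chain in place of the methyl, or with a chlorine in place of the bromine.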